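This account rests on a few compounds, and the source may have more. Where it says the series, first, only, none or still open, it means among the compounds named here.

Measured so far:
compound 1 `Cc1cc(N2CC[C@@H](C)[C@@H](N(C)c3ncnc4[nH]ccc34)C2)n2nc(SCc3ccccc3Br)nc2n1` — > 100000 nM
compound 2 `Cc1nc2nc(SCc3ccc(Cl)cc3)nn2c(N2CC[C@@H](C)[C@@H](N(C)c3ncnc4[nH]ccc34)C2)c1C` — 99200 nM

In a toxicity assay on GES1 cells (Homo sapiens) for inhibition, read by MTT assay, with a stated time of 72 h (a higher number here means a weaker inhibitor, a lower number a stronger inhibitor), compound 1 gives > 100000 nM, which is a limit of the assay and not a number. In this assay compound 2 gives 99200 nM. Compound 1 stands at the limit of > 100000 nM in this assay, at which 1 of the 2 values shown sits.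

Compound 3 `Cc1cc(N2CC[C@@H](C)[C@@H](N(C)c3ncnc4[nH]ccc34)C2)n2nc(SCc3ccc(F)c(Cl)c3)nc2n1` is the next to be measured. The change from compound 1 is 3-chloro-4-fluorophenyl in place of 2-bromophenyl on a saturated chain carbon bound to a sulfur. Within the data shown here, no measured step frames this change, and a shift beyond the scatter is not expected in either direction. Compound 3 is therefore expected to give 100000 nM, between 50000 nM and 200000 nM, the step being a number no higher from compound 1 to compound 3 (the limit leaves the size open).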

Compound 3, half-maximal inhibitory concentration: > 100000 nM
Compound 3 was reported as a limit (the forecaster's own chance of this, stated with the estimate: 60%); the middle value sits exactly at the limit.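

Among these compounds, no step from compound 1 to compound 3 can be read in this assay, because both compounds sit at a limit of the assay and not at a number: the limit of > 100000 nM in this assay, at which 2 of the 3 values shown sit.

The compounds shown leave open whether exchanging 2-bromobenzyl for 3-chloro-4-fluorobenzyl changes the half-maximal inhibitory concentration at all.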